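The source may hold more compounds than are shown below. What is called first, only, known or untested is meant among the compounds shown, and "the series" means these compounds.

In a toxicity assay on microsomes from liver (Homo sapiens) for metabolic stability, read by LC-MS, using NADPH, tested at 1 uM (a lower number here means slower removal, a higher number faster removal of the compound), compound 1 `CCOc1ncc(-c2nc(C(F)(F)F)sc2N2CCN(C(=O)Cn3ccc4cnccc43)[C@H](C)C2)cn1` gives 656 mL.min-1.g-1, and compound 2 `CCOc1ncc(-c2nc(C(F)(F)F)sc2N2CCN(C(=O)Cn3ncc4cccnc43)[C@H](C)C2)cn1` gives 41 mL.min-1.g-1. That is a 16-fold lower number from compound 1 to compound 2 (1.20 log units; beyond the scatter), a large move at the group on the saturated chain carbon, away from the place changed here. Compound 3 `Cc1ncc(-c2nc(C(F)(F)F)sc2N2CCN(C(=O)Cn3nc(C)nc3C)[C@H](C)C2)cn1` gives < 10 mL.min-1.g-1, which is a limit of the assay and not a number. Compound 4 `COc1ccc(-c2nc(C(F)(F)F)sc2N2CCN(C(=O)Cn3nc(C)nc3C)[C@H](C)C2)cn1` carries 6-methoxypyridin-3-yl in place of 2-methylpyrimidin-5-yl on an aromatic carbon. Within the data shown here, no measured step covers this place, so a 16-fold lower number from compound 1 to compound 2 (1.20 log units; beyond the scatter) serves only as a guide to how far this assay can move. The expected step, an at least 2.2-fold higher number from compound 3 to compound 4 (0.34 log units; beyond the scatter), is upward and moderate, smaller than that measured one. Compound 4 is estimated at 22 mL.min-1.g-1, with an expected range of 10 mL.min-1.g-1 to 80 mL.min-1.g-1.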

Compound 4, intrinsic clearance in microsomes: < 10 mL.min-1.g-1
Compound 4: only a limit was reported (the forecaster's own chance of this, stated with the estimate: 25%); at least 2.2-fold (0.34 log units) between middle value and limit.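

No step can be read from compound 3 to compound 4, as each result is only a limit: the limit of < 10 mL.min-1.g-1 in this assay, at which 2 of the 4 values shown sit. From the compounds shown here alone, whether 6-methoxypyridin-3-yl in place of 2-methylpyrimidin-5-yl changes the result in this assay remains open.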